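The compounds below may be only part of what the source reports. "The series", "measured", "known", "first", "only" and "open" are said of these compounds alone.

Of the compounds shown here, two with a shared core have been tested in a functional assay on the whole organism (artery, strain albino) with Rattus norvegicus as the target, with a stated time of 240 min, at a dose of 10 mg/kg by the oral route; a higher number here means more inhibition at the dose given (going by the name of the read-out), a lower number less inhibition. Compound 1 `COc1ccc(C2N=C(SCc3ccc(Cl)cc3)NC(C)=C2C(=O)Nc2ccc(F)cc2)cc1OC` gives 24.1% in this assay. Compound 2 `CC1=C(C(=O)Nc2ccc(F)cc2)C(c2ccc([N+](=O)[O-])cc2)N=C(SCc2cccc(Cl)c2)N1` gives 15.9% in this assay, and its number lies within the usual scatter of repeated measurements of that of compound 1, so the two cannot be told apart on these data. Compound 3 `CC1=C(C(=O)Nc2ccc(F)cc2)C(c2ccc([N+](=O)[O-])cc2)N=C(SCc2ccc(Cl)cc2)N1` has not yet been measured. It differs from compound 2 in one place: 4-chlorophenyl in place of 3-chlorophenyl on a saturated chain carbon bound to a sulfur. The 4-chlorobenzyl group that enters is also present in compound 1, whose result in this assay sits close to that of compound 2. Among the measured compounds shown here, no measured step of this kind exists to go by, so the step from compound 2 to compound 3 is expected to be a number 4.1 percentage points higher from compound 2 to compound 3 (within the scatter), none beyond the scatter. Compound 3 is therefore estimated at 20% in this assay, with a range from 8% to 32%.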

Compound 3, a percentage reported as inhibition, in the whole organism at one dose (the size of the read-out at that dose, not a potency): 33.3%
Beside the measured number, compound 3's estimate is 13.3 percentage points below it; the measured number lies above the stated range.
By their numbers in this assay, from the lowest: compounds 2, 1 and 3 (each within the scatter of the next, the first and the last beyond it).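

Among the compounds shown here, the two groups have the same atoms joined differently, yet in this assay the change from 3-chlorophenyl to 4-chlorophenyl on a saturated chain carbon bound to a sulfur gives a number 17.4 percentage points higher from compound 2 to compound 3 (beyond the scatter), the first step in this set that lies beyond the scatter and so the first sign that this position can tell such closely related groups apart. With the 4-chlorobenzyl group held constant, 4-nitrophenyl in place of 3,4-dimethoxyphenyl on a saturated ring carbon gives a number 9.2 percentage points higher from compound 1 to compound 3 (within the scatter), so these two groups cannot be told apart at that place. No measurement here offers a reason for the larger step.

Still open, from the compounds shown here alone, is whether the same chlorophenyl change gives a similar step with 3,4-dimethoxyphenyl on the ring carbon. So is how a plain benzyl group, a 4-methoxybenzyl group or a longer chain such as phenethyl would fare on the sulfur.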